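A few compounds are considered here, and "the series" means these few. Any claim that something is new, unique, unknown or untested is made for them only; others in the source may bear on it.

In a functional assay on EC9706 cells (Homo sapiens) for antiproliferative activity, read by MTT assay, with a stated time of 48 h (on this read-out lower numbers stand for stronger inhibition and higher numbers for weaker inhibition), three compounds with a shared core and different saturated chains have been measured so far. Compound 1 `CCCCCCCn1cc(COC[C@@H]2OC[C@H](N)[C@H]2O)nn1` gives > 128000 nM, which is a limit and not a number. Compound 2 `CCCCCCCCn1cc(COC[C@@H]2OC[C@H](N)[C@H]2O)nn1` gives > 128000 nM, also a limit. Compound 3 `CCCCCCCCCn1cc(COC[C@@H]2OC[C@H](N)[C@H]2O)nn1` gives > 128000 nM, again a limit, so it has no exact position on the scale. The whole record so far is the limit of > 128000 nM in this assay, at which 3 of the 3 values shown sit.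

Compound 4 `CCCCCCCCCCn1cc(COC[C@@H]2OC[C@H](N)[C@H]2O)nn1` differs from compound 3 by one change: methyl in place of hydrogen on a saturated chain carbon, nine bonds along the chain from an aromatic nitrogen. In words, this is methyl in place of hydrogen on a saturated chain carbon, nine bonds along the chain from an aromatic nitrogen.

Three measured steps of the same kind bear on it: a step that the two limits leave unreadable from compound 1 to compound 2, a step that the two limits leave unreadable from compound 2 to compound 3 and a step that the two limits leave unreadable from compound 1 to compound 3. None of them has a readable size, so they offer no trend to extend. Compound 4 is therefore expected to remain weak in this assay, with compound 3 as the guide through a step that the two limits leave unreadable from compound 2 to compound 3. The expected change is small, if any, and toward stronger inhibition: an at least 1.2-fold lower number from compound 3 to compound 4 (0.10 log units; that floor lies within the scatter). For compound 4 the estimate is 100000 nM, with an expected range of 40000 nM to 180000 nM.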

Compound 4, half-maximal inhibitory concentration: 43100 nM
The estimate for compound 4 lay 2.3-fold (0.37 log units) above the measured number; the range from low to high includes it.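

Compound 4 is the only one of these four chains with an exact number in this assay, so methyl in place of hydrogen on a saturated chain carbon, nine bonds along the chain from an aromatic nitrogen, gives a change with a readable direction: an at least 2.9-fold lower number from compound 3 to compound 4 (0.47 log units; beyond the scatter). Compared with the two shorter chains, compound 4 shows an at least 2.9-fold lower number from compound 2 to compound 4 (0.47 log units; beyond the scatter) and an at least 2.9-fold lower number from compound 1 to compound 4 (0.47 log units; beyond the scatter). These sizes are only floors and the steps among compounds 1, 2 and 3 cannot be read, since those three compounds share one limit: the limit of > 128000 nM in this assay, at which 3 of the 4 values shown sit.

With a single exact number, the compounds shown establish no trend along the chain. Going by these compounds, whether a longer chain lowers the number further remains open, as does what an amine or a carboxylic acid at the chain end would do.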